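The source may report more compounds than this note shows. Statements on the series, on what has been measured and on what is new or still open speak of the compounds shown alone.

Measured so far:
compound 1, `O=C1/C(=C/c2ccc(F)cc2)Cc2ccccc21`: 60000 nM
compound 2, `O=C1/C(=C/c2ccc(Cl)cc2)Cc2ccccc21`: a limit of the assay, > 500000 nM
compound 3, `O=C1CCCCC/C1=C\c1cccc(F)c1`: 482000 nM

In a functional assay on MOLT-4 cells (Homo sapiens) for inhibition (a lower number here means a stronger inhibitor, a higher number a weaker inhibitor), compound 1 gives 60000 nM. For compound 2 the assay reports only a limit, > 500000 nM. The change between them is chloro in place of fluoro on an aromatic carbon, and the step is an at least 8.3-fold higher number from compound 1 to compound 2 (0.92 log units; beyond the scatter); its size is bounded by the limit of > 500000 nM in this assay, at which 1 of the 3 values shown sits. Compound 3 gives 482000 nM in this assay. The difference between the core of compound 1 and the core of compound 3 is not broken down here.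

Compound 4, `O=C1CCCCC/C1=C\c1cccc(Cl)c1`, is not yet measured. It differs from compound 3 by chloro in place of fluoro on an aromatic carbon. Among the compounds with values here, this is the same kind of change as the one from compound 1 to compound 2, though the place is not identical: there it sits para to a large group, here meta to a group of 9 heavy atoms. Because the earlier step was an at least 8.3-fold higher number from compound 1 to compound 2 (0.92 log units; beyond the scatter) and compound 3 already gives 482000 nM, a weakening is expected, and the step is estimated as a 2.5-fold higher number from compound 3 to compound 4 (0.40 log units; beyond the scatter). Compound 4 is therefore expected to give about 1200000 nM in this assay, between 350000 nM and 4000000 nM, quite possibly reported only as a limit.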

Compound 4, half-maximal inhibitory concentration: 88600 nM
For compound 4 the middle estimate is 14-fold (1.13 log units) above the measured one; the measured number lies below the stated range.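

In this assay, the same exchange of fluoro for chloro on an aromatic carbon does not carry over from one core to the other: it strengthens inhibition on the second core, a 5.4-fold lower number from compound 3 to compound 4 (0.74 log units; beyond the scatter), whereas it weakened inhibition on the first, and the two steps clearly differ: the same change on two cores in this assay, an at least 8.3-fold higher number (0.92 log units; beyond the scatter) from compound 1 to compound 2 and a 5.4-fold lower number (0.74 log units; beyond the scatter) from compound 3 to compound 4, at least 45-fold (1.65 log units) apart, beyond the scatter of two such steps. Compound 2 is known only through a limit of the assay, > 500000 nM. These two pairs show that the result of this change depends on its setting, but they do not show whether the core itself or the place of the change on the aromatic ring is what matters, since the two pairs differ in both, and they give no rule for other cores.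

Going by these compounds, it remains open how fluoro and chloro compare when they sit at the same place on both cores. On these data alone, it also remains open whether a bromo or methyl group at these places would follow the chloro or the fluoro compounds.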